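Fluorophenyl change from compound 1 to compound 3

The source may report more compounds than this note shows. Statements on the series, on what has been measured and on what is new or still open speak of the compounds shown alone.

- compound 1 `Fc1ccc(N2CCN(CCN3CCN(c4ccc(F)cc4)CC3)CC2)cc1`: 71200 nM
- compound 2 `O=[N+]([O-])c1cc(C(F)(F)F)ccc1N1CCN(CCN2CCN(c3ccc(C(F)(F)F)cc3[N+](=O)[O-])CC2)CC1`: 63200 nM

In a functional assay on LNCaP cells (Homo sapiens) for cytotoxicity, read by MTT assay, with a stated time of 24 h (a higher number here means that more compound is needed for the effect, a lower number that less compound is needed), compound 1 gives 71200 nM and compound 2 gives 63200 nM. Among the compounds with values here, these two values lie within the scatter of each other, so compound 1 stands level with compound 2 on the numbers so far.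

The unmeasured compound 3 `Fc1ccc(N2CCN(CCN3CCN(c4ccccc4F)CC3)CC2)cc1` differs from compound 1 in one place: 2-fluorophenyl in place of 4-fluorophenyl on an amine nitrogen in a ring. It has 2-fluorophenyl in place of 4-fluorophenyl on an amine nitrogen in a ring.

Within the data shown here, the measured pair differs in more than one place, so no single-place step is available as a guide. Set against compound 1, compound 2 carries other substituents and still gives 63200 nM, so no step beyond the scatter is expected in this assay. The estimated change is a 1.1-fold lower number from compound 1 to compound 3 (0.06 log units; within the scatter). Compound 3 is expected at 62000 nM, with an estimated range of 28000 nM to 130000 nM.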

Compound 3, half-maximal effective concentration: 68000 nM
Estimate against measurement, compound 3: 1.1-fold (0.04 log units) below; measured number inside the range.
By their numbers in this assay, from the lowest: compounds 2, 3 and 1 (each within the scatter of the next).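

Within the data shown here, the only single-place step, a 1.0-fold lower number from compound 1 to compound 3 (0.02 log units; within the scatter) in this assay, puts 2-fluorophenyl and 4-fluorophenyl level on this amine nitrogen in a ring. The two compounds have the same atoms, joined differently, so this step gives a direct reading of this position, which the comparison of compound 1 with compound 2 could not give: for these two groups, where the fluorine sits on the phenyl leaves the number within the scatter. No measurement at hand offers an explanation for this result.

On these data alone, whether a plain phenyl, a methoxyphenyl or a pyridine at this place would give a step beyond the scatter remains open. So does the effect of a longer chain in the shared core.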